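The source may hold more compounds than are shown below. What is called first, only, known or untested is meant among the compounds shown, and "the series" means these compounds.

Measured so far:
compound 1 `COCC(C(=O)N1CCN(c2cccc(C(F)(F)F)c2)CC1)N1C(=O)CCC1=O` — 100% in a functional assay on the whole organism (strain Swiss) with Mus musculus as the target, in the maximal electroshock model, with a stated time of 0.25 h, at a dose of 100 mg/kg by the intraperitoneal route; on this read-out lower numbers stand for a weaker effect and higher numbers for a stronger effect at the one dose given
compound 2 `CC(C(=O)N1CCN(c2ccccc2)CC1)N1C(=O)CCC1=O` — 50%
compound 3 `CCC(C(=O)N1CCN(c2cccc(C(F)(F)F)c2)CC1)N1C(=O)CCC1=O` — 75%

Compound 3 stands second highest of the three numbers: compound 1 lies beyond the scatter above it, compound 2 beyond the scatter below it. Compound 4 `CC(C(=O)N1CCN(c2cccc(C(F)(F)F)c2)CC1)N1C(=O)CCC1=O` differs from compound 3 by hydrogen in place of methyl on a saturated chain carbon, two bonds along the chain from an amide-type nitrogen in a ring and a carbonyl carbon. For the measured compounds named here, the one measured step that bears on this chain carbon is a number 25 percentage points lower from compound 1 to compound 3 (beyond the scatter), a modest fall when the group there was shortened. Compound 2, which carries the same methyl group on that carbon, shows 50%, but it also differs elsewhere, so only its value can be compared. Compound 4 is therefore expected to fall a number 20 percentage points lower from compound 3 to compound 4 (beyond the scatter), to an estimated 55%, with a range of 30% to 80%.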

Compound 4, a percentage reported as activity, at one dose (the size of the read-out at that dose, not a potency): 50%
Compound 4: middle estimate off by 5 percentage points, on the high side, within the range that was stated.
By their numbers in this assay, from the lowest: compounds 2 and 4 (each within the scatter of the next); then compound 3; then compound 1.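

In this assay, taking the chain group down one carbon further also lowers the number (a number 25 percentage points lower from compound 3 to compound 4 (beyond the scatter)), and the full change from methoxy to hydrogen at this position gives a large fall (a number 50 percentage points lower from compound 1 to compound 4 (beyond the scatter)), so the listed series falls at each shortening. With this shortest group, trifluoromethyl on the aromatic ring leaves the read-out unmoved (no change at the digits printed from compound 2 to compound 4 (within the scatter)). Nothing measured here explains these steps.

Going by these compounds, it remains open whether a longer chain, an amine or a carboxylic acid at this chain carbon would match the methoxy-bearing compound 1. On these data alone, it also remains open whether trifluoromethyl matters when a larger group sits there.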